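The source may hold more compounds than are shown below. What is called first, only, known or untested is meant among the compounds shown, and "the series" means these compounds.

In an ADME assay on NIH3T3 cells (Mus musculus) for cytotoxicity, read by MTT assay, with a stated time of 24 h (a lower number here means a stronger inhibitor, a higher number a weaker inhibitor), compound 1 `Cc1ccc(-c2nnc(N3CCN(C(=O)CN4CCN(c5ccccc5)CC4)CC3)nc2-c2ccc(C)cc2)cc1` reaches only a limit, > 914000 nM. Compound 2 `COc1ccc(-c2nnc(N3CCN(C(=O)CN4CCN(c5ccc(OC)cc5)CC4)CC3)nc2-c2ccc(OC)cc2)cc1` likewise reaches only a limit, > 821000 nM. Compound 3 `COc1ccccc1N1CCN(CC(=O)N2CCN(c3nnc(-c4ccc(Cl)cc4)c(-c4ccc(Cl)cc4)n3)CC2)CC1` gives 405000 nM.

Among the compounds with values here, compound 3 is thus the only one of the three with a number in this assay; the other two sit at limits, the limit of > 821000 nM in this assay, at which 1 of the 3 values shown sits, and (the limit of > 914000 nM in this assay, at which 1 of the 3 values shown sits), so no measured step between compounds is available. Compound 4 `COc1ccc(N2CCN(CC(=O)N3CCN(c4nnc(-c5ccc(Cl)cc5)c(-c5ccc(Cl)cc5)n4)CC3)CC2)cc1` differs from compound 3 in one place: 4-methoxyphenyl in place of 2-methoxyphenyl on an amine nitrogen in a ring. Within the data shown here, with no measured step to lean on, the step from compound 3 to compound 4 is expected to be small, a 1.2-fold higher number from compound 3 to compound 4 (0.09 log units; within the scatter), within the scatter or slightly toward weaker inhibition. Compound 4 is therefore estimated at 500000 nM, with a range from 200000 nM to 1500000 nM.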

Compound 4, half-maximal inhibitory concentration: > 809000 nM
Compound 4 gave a limit, no number (the forecaster's own chance of this, stated with the estimate: 40%); at least 1.6-fold (0.20 log units) between middle value and limit.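

Within the data shown here, this is the first step that can be read: in this assay, 4-methoxyphenyl in place of 2-methoxyphenyl on an amine nitrogen in a ring gives an at least 1.9-fold higher number from compound 3 to compound 4 (0.30 log units; that floor lies within the scatter). The two compounds carry the same atoms, so this step reflects only how they are joined. Compound 4 reaches only a limit, so the step has a floor but no measured size: the limit of > 809000 nM in this assay, at which 1 of the 4 values shown sits.

As far as these compounds go, it remains open how large the step really is. From the compounds shown here alone, it also remains open whether an amine or a hydroxyl group in place of the methoxy group would give a number in this assay.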